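The source may hold more compounds than are shown below. What is called first, only, known or untested is meant among the compounds shown, and "the series" means these compounds.

Compound 1 `O=C1CCCCC/C1=C\c1ccc(F)cc1` gives 250000 nM
Compound 2 `O=C1CCCCC/C1=C\c1ccc(Br)cc1` gives 49400 nM

In a functional assay on MOLT-4 cells (Homo sapiens) for inhibition (a higher number here means a weaker inhibitor, a lower number a stronger inhibitor), compound 2 gives 49400 nM and so holds the lower of the two numbers, which makes it the stronger inhibitor of this pair. The next compound to be tested is compound 3 `CN(C)c1ccc(/C=C2\CCCCCC2=O)cc1`. Its structure has dimethylamino in place of bromo on an aromatic carbon. Within the data shown here, only one measured step bears on this change (a 5.1-fold lower number from compound 1 to compound 2 (0.70 log units; beyond the scatter)). Among the measured compounds shown here, that modest step has bromo in place of fluoro on an aromatic carbon, and no measured compound carries dimethylamino. It therefore offers a rough guide to size but none to direction. For the measured compounds named here, no step clearly beyond the scatter can be predicted either way, so the expected step is small and uncertain (a 1.2-fold higher number from compound 2 to compound 3 (0.08 log units; within the scatter)). Compound 3 is estimated at 60000 nM in this assay with a range of 15000 nM to 250000 nM expected for it.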

Compound 3, half-maximal inhibitory concentration: 57400 nM
Compound 3: the middle estimate sits 1.0-fold (0.02 log units) above what was measured; the range from low to high includes it.
By their numbers in this assay, from the lowest: compounds 2 and 3 (each within the scatter of the next); then compound 1.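

In this assay, the position on the aromatic ring tolerates a large change of group: dimethylamino, with 3 heavy atoms and a hydrogen-bond acceptor, replaces bromo, with 1 heavy atom and no acceptor, and the result is a 1.2-fold higher number from compound 2 to compound 3 (0.07 log units; within the scatter). Set against fluoro, dimethylamino gives a 4.4-fold lower number from compound 1 to compound 3 (0.64 log units; beyond the scatter), so among these three compounds it is compound 1, the fluoro compound, that stands apart, while compound 2 and compound 3 cannot be told apart. Nothing measured here explains why these groups compare as they do.

From the compounds shown here alone, it remains open whether a methoxy group, a carboxylic acid or a plain hydrogen at this place would match compound 2 and compound 3 or fall nearer compound 1. Going by these compounds, it is also open whether bromo and dimethylamino would match each other elsewhere on the aromatic ring.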